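A few compounds are considered here, and "the series" means these few. Any claim that something is new, unique, unknown or untested is made for them only; others in the source may bear on it.

Measured so far:
- compound 1 `Cn1cc(-c2cc(NS(C)(=O)=O)ccc2Oc2ccc(F)cc2Cl)c2cc[nH]c2c1=O`: 233 mL/min/kg
- compound 2 `Cn1cc(-c2cc(NS(C)(=O)=O)ccc2Oc2ccc(F)cc2F)c2cc[nH]c2c1=O`: 155 mL/min/kg

Both compounds were run in an ADME assay on microsomes from liver (Homo sapiens) for metabolic stability, read by HPLC, using NADPH, with stated times of 5 min and 60 min, tested at 10 uM; a lower number here means slower removal, a higher number faster removal of the compound. Compound 1 gives 233 mL/min/kg and compound 2 gives 155 mL/min/kg. The one step shown, a 1.5-fold lower number from compound 1 to compound 2 (0.18 log units; within the scatter), is within the scatter, so the two numbers cannot be ordered; compound 2 simply holds the lower of the two figures.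

Compound 3 `Cn1cc(-c2cc(NS(C)(=O)=O)ccc2Oc2cccnc2)c2cc[nH]c2c1=O` is not yet measured. It differs from compound 2 by pyridin-3-yl in place of 2,4-difluorophenyl on an oxygen on an aromatic ring. Going by the values given here, no measured step touches this change: the only step available swaps one halogen for another on the same ring, and it was within the scatter. Among the compounds with values here, nothing among the measured compounds speaks for or against a move in either direction, and a pyridine ring in place of a carbocycle is a larger change than the one seen. The working expectation is therefore a value near that of compound 2, with a wide range on both sides; the estimated step of a 1.2-fold lower number from compound 2 to compound 3 (0.08 log units; within the scatter) is taken as no change beyond the scatter. For compound 3 the estimate is 130 mL/min/kg, range 50 mL/min/kg to 300 mL/min/kg.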

Compound 3, clearance: 86.7 mL/min/kg
The estimate for compound 3 lay 1.5-fold (0.18 log units) above the measured number; measured number inside the range.
By their numbers in this assay, from the lowest: compounds 3, 2 and 1 (each within the scatter of the next, the first and the last beyond it).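

In this assay the swap of the whole ring on the oxygen, and not just of one halogen, gives a 1.8-fold lower number from compound 2 to compound 3 (0.25 log units; within the scatter) and so does not set compound 3 apart from compound 2. Going by these compounds alone, measured against the chlorine-bearing ring, the same pyridin-3-yl gives a 2.7-fold lower number from compound 1 to compound 3 (0.43 log units; beyond the scatter) and this is the first step to clear the scatter, although it is modest and compound 2 sits within the scatter of both neighbours, so the ring on this oxygen can be said to move the number only between the two ends of the set. No measurement on hand bears on what lies behind these steps.

Compound 3 differs from the halogenated compounds both by a ring nitrogen and by the absence of halogen, and the set does not separate these two changes; an unsubstituted phenyl on the same oxygen would do so. Also open, going by these compounds, is how a saturated amine such as piperidin-4-yl, or a carboxylic acid on the ring, would read at this position, and whether pyridin-2-yl or pyridin-4-yl would read as pyridin-3-yl does.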